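Pyrazin-2-yl for (pyridin-4-yl)methyl on the ring amine

The source may report more compounds than this note shows. Statements on the series, on what has been measured and on what is new or still open speak of the compounds shown alone.

Measured compounds:
compound 1, `CN(Cc1cccnc1)C(=S)SCc1ccc(C(=O)Nc2ccccc2N)cc1`; in a functional assay on MGC-803 cells (Homo sapiens) for antiproliferative activity, read by CCK-8 assay, with a stated time of 72 h, tested at 8 uM (a lower number here means a weaker effect, a higher number a stronger effect of the compound at the concentration tested), compound 1 gives 85.5%
compound 2, `Nc1ccccc1NC(=O)c1ccc(CSC(=S)N2CCN(Cc3ccncc3)CC2)cc1`; in this assay compound 2 gives 79.3%

Compound 2 holds the lower of the two numbers in this assay, but its nearest neighbour, compound 1, sits only a little higher and the two values lie within the scatter of each other, so no order between them can be read.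

The next compound is compound 3, `Nc1ccccc1NC(=O)c1ccc(CSC(=S)N2CCN(c3cnccn3)CC2)cc1`. It differs from compound 2 in one place: pyrazin-2-yl in place of (pyridin-4-yl)methyl on an amine nitrogen in a ring. The group that leaves and the group that enters are both single six-membered aromatic rings; the change removes the one-carbon link to the ring amine nitrogen and adds one ring nitrogen.

Within the data shown here, no step between two measured compounds is available to size this change, and nothing in the two values at hand points in either direction. For this assay the expected step from compound 2 to compound 3 is therefore none beyond the scatter, a number 4.3 percentage points lower from compound 2 to compound 3 (within the scatter). Compound 3 is estimated at 75%, with a range from 55% to 90%.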

Compound 3, a percentage reported as inhibition, at one concentration (the size of the read-out at that concentration, not a potency): 80.5%
Estimate against measurement, compound 3: 5.5 percentage points below, within the range that was stated.
By their numbers in this assay, from the lowest: compounds 2, 3 and 1 (each within the scatter of the next).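

In this assay, the first step readable on the amine nitrogen in a ring is a number 1.2 percentage points higher from compound 2 to compound 3 (within the scatter), so this position accepts pyrazin-2-yl in place of (pyridin-4-yl)methyl without a readable shift in the read-out. Among these compounds, the exchange alters two things at once, the link to the ring amine nitrogen and the number of ring nitrogens, and this single step shows no separable contribution from either one, only that the pair together leaves the number inside the scatter. No measurement at hand bears on why the two groups read alike.

The read-out is the size of the effect at one concentration and not a potency, so compounds 2 and 3 could still differ at lower concentrations, and the series gives no way to tell from these numbers alone. Also open, from the compounds shown here alone, is whether the position stays this permissive for groups of another kind on the ring amine nitrogen, such as a plain phenyl, an acetyl or a longer chain ending in a pyridine ring, any of which could show whether a step beyond the scatter can be found here at all.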